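The compounds below may be only part of what the source reports. "The series", "measured", "known", "first", "only" and "open" are said of these compounds alone.

Measured so far:
compound 1, `CCCCCCCCNc1cnc(C(=O)NCc2ccccc2)cn1` — 100000 nM
compound 2, `O=C(NCc1ccccc1)c1cnc(Cl)cn1` — "not determined" (no result reported)

Compound 1, whose structure is `CCCCCCCCNc1cnc(C(=O)NCc2ccccc2)cn1`, has been tested in an ADME assay on HEL cells (Homo sapiens) for cytotoxicity, read by microscopy, with a stated time of 6 days (a higher number here means that more compound is tolerated, a lower number that less compound is tolerated), and gives 100000 nM. Compound 2, with the structure `O=C(NCc1ccccc1)c1cnc(Cl)cn1`, shares the same core, but in this assay compound 2 stands at "not determined" (no result reported), so no single number places it on this scale.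

The step under study leads from compound 2 to compound 3, whose structure is `CCCCNc1cnc(C(=O)NCc2ccccc2)cn1`. The change is butylamino in place of chloro on an aromatic carbon. Among the compounds with values here, with no measured pair of this kind to draw on, the size of the step in this assay cannot be read from the data; compound 1 is the only anchor. Because compound 1 gives 100000 nM with the same core and a related group at the same ring carbon, compound 3 is expected to land close to that number, with no shift beyond the usual scatter anticipated. The tolerated concentration for compound 3 in this assay is therefore estimated at 100000 nM, within a range from 50000 nM to 200000 nM.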

Compound 3, minimum cytotoxic concentration: > 100000 nM
Compound 3 ended at the assay's limit (the forecaster's own chance of this, stated with the estimate: 40%); the middle value lies on the limit itself.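

In this assay compound 3 gives > 100000 nM, which is a limit of the assay and not a number. Shortening the octylamino chain to butylamino at this ring carbon gives a number no lower from compound 1 to compound 3 (the limit leaves the size open), so this change brings no loss in the concentration tolerated. The change from chloro to butylamino has no size of its own, since compound 2 has no number on this scale, and the size of the chain step stays unread because of the limit: the limit of > 100000 nM in this assay, at which 1 of the 3 values shown sits.

The compounds shown leave open whether a much shorter chain, such as methylamino, or a carboxylic acid at this carbon would shift the reading. They also leave open whether any group at this position would lower the tolerated concentration in this assay.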